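Swapping Benzyl for Methyl at Selenium: What to Expect

This account rests on a few compounds, and the source may have more. Where it says the series, first, only, none or still open, it means among the compounds named here.

compound 1 `C[Se]/C(=N\C(=O)c1cccs1)NC(=O)c1cccs1` — > 100000 nM
compound 2 `O=C(/N=C(/NC(=O)c1cccs1)[Se]Cc1ccccc1)c1cccs1` — > 100000 nM
compound 3 `O=C(/N=C(/NC(=O)c1csc([N+](=O)[O-])c1)[Se]Cc1ccccc1)c1csc([N+](=O)[O-])c1` — 83800 nM

In a functional assay on MCF7 cells (Homo sapiens) for cytotoxicity, read by MTT assay, with a stated time of 72 h (a higher number here means that more compound is tolerated, a lower number that less compound is tolerated), compound 1 reports only a limit, not a number. Compound 2 likewise reports only a limit in this assay. Between them lies (hydrogen in place of phenyl on a saturated chain carbon bound to a selenium atom), and the resulting step that the two limits leave unreadable from compound 2 to compound 1 cannot be read because the limit of > 100000 nM in this assay, at which 2 of the 3 values shown sit, hides both ends. Within the data shown here, compound 3 carries a core whose difference from compound 2 is not broken down here; in this assay compound 3 gives 83800 nM, the only true number in the set. Compound 4 `C[Se]/C(=N\C(=O)c1csc([N+](=O)[O-])c1)NC(=O)c1csc([N+](=O)[O-])c1` applies the same change to compound 3: hydrogen in place of phenyl on a saturated chain carbon bound to a selenium atom. With the earlier step unreadable, the expectation for compound 4 is a step of about a 1.2-fold higher number from compound 3 to compound 4 (0.08 log units; within the scatter), resting on compound 3 sitting close to the limit of > 100000 nM in this assay, at which 2 of the 3 values shown sit. Compound 4 is therefore estimated at 100000 nM, between 40000 nM and 250000 nM.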

Compound 4, concentration lethal to 50% of the cells: > 100000 nM
Compound 4 ended at the assay's limit; the forecaster's own chance of this, stated with the estimate: 50%; the middle value sits exactly at the limit.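

Carried to the second core, the same swap of benzyl for methyl gives, in this assay, an at least 1.1-fold higher number from compound 3 to compound 4 (0.07 log units; that floor lies within the scatter). This figure is only a floor, so the true size of the step stays hidden, and the result shows no more than that the methyl compound also ends at the limit, because the values pile up there: the limit of > 100000 nM in this assay, at which 3 of the 4 values shown sit. The step on the first core cannot be read at all, so the data cannot show whether the change has the same effect on both cores.

The compounds shown leave open what a longer chain, such as propyl, would do in place of benzyl or methyl. A chain ending in an amine or a carboxylic acid is also left open.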